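Lengthening One Amine Arm on a Shared Core

The compounds below may be only part of what the source reports. "The series", "measured", "known", "first", "only" and "open" are said of these compounds alone.

Compounds measured so far:
compound 1, `CCCCNc1cc(C)nc2c(-c3ccc(Cl)cc3Cl)nn(C)c12`, 170 nM
compound 2, `CCCCN(CCCC)c1cc(C)nc2c(-c3ccc(Cl)cc3Cl)nn(C)c12`, 0.62 nM
compound 3, `CCN(CCCOC)c1cc(C)nc2c(-c3ccc(Cl)cc3Cl)nn(C)c12`, 12.5 nM

Three compounds share one core and differ only in the amino group on an aromatic carbon. In an assay on HEK293 cells for displacement of a labelled ligand from corticotropin-releasing factor receptor 1 (Homo sapiens) (on this read-out lower numbers stand for stronger inhibition and higher numbers for weaker inhibition), compound 3 gives 12.5 nM, which places it second highest of the three numbers: above compound 2, below compound 1. Compound 4, `CCCCN(CCCOC)c1cc(C)nc2c(-c3ccc(Cl)cc3Cl)nn(C)c12`, has not been measured. Relative to compound 3 the change is ethyl in place of hydrogen on a saturated chain carbon, two bonds along the chain from a nitrogen on an aromatic ring, so that the ethyl arm of the amine becomes a butyl arm while the 3-methoxypropyl arm is kept.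

Among the compounds with values here, two measured steps bear on this. Adding a butyl to the nitrogen gave a 270-fold lower number from compound 1 to compound 2 (2.44 log units; beyond the scatter), a large effect. Replacing dibutylamino with ethyl(3-methoxypropyl)amino gave a 20-fold higher number from compound 2 to compound 3 (1.30 log units; beyond the scatter). Compound 4 sits between compound 2 and compound 3 in structure, carrying one butyl arm and one 3-methoxypropyl arm, so the number is expected to move back toward that of compound 2, though not all the way, because a 20-fold higher number from compound 2 to compound 3 (1.30 log units; beyond the scatter) changed both arms, while here only one arm is changed.

The expected step is therefore a 4.2-fold lower number from compound 3 to compound 4 (0.62 log units; beyond the scatter), a lower number. Compound 4 is estimated at 3 nM, with a likely range from 1 nM to 10 nM.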

Compound 4, inhibition constant: 18 nM
Compound 4: the middle estimate sits 6.0-fold (0.78 log units) below what was measured, outside the stated range (above it).
By their numbers in this assay, from the lowest: compound 2; then compounds 3 and 4 (each within the scatter of the next); then compound 1.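

Within this assay, lengthening the ethyl arm to a butyl arm while the 3-methoxypropyl arm is kept gives a 1.4-fold higher number from compound 3 to compound 4 (0.16 log units; within the scatter) and so leaves the read-out within the scatter, which the steps among compounds 1, 2 and 3 could not show. With the butyl arm held fixed, methoxy in place of methyl on the other arm, three bonds along the chain from the nitrogen, gives a 29-fold higher number from compound 2 to compound 4 (1.46 log units; beyond the scatter) as a large step, so the gap between the dibutylamino compound and the two methoxy-bearing amines follows the methoxy arm in this pair and not the length of the second arm. On the nitrogen of compound 1, 3-methoxypropyl in place of hydrogen gives a 9.4-fold lower number from compound 1 to compound 4 (0.98 log units; beyond the scatter) as a modest step, whereas butyl in that same place gave a 270-fold lower number from compound 1 to compound 2 (2.44 log units; beyond the scatter) as a large one.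

As far as these compounds go, whether a hydroxy group or an amine in place of that methoxy would bring the number back toward that of compound 2 stays open, as does the effect of a pentyl arm in place of the butyl arm. Nothing shown here gives a reason for any of these steps.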